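This account rests on a few compounds, and the source may have more. Where it says the series, first, only, none or still open, it means among the compounds named here.

Compound 3 `CCN1CCN(CCCn2cnc3c(N4CCN(C5CCCC5)CC4)nc(N)nc32)CC1` gives 280 nM in an assay on HEK293 cells for antagonist activity at Toll-like receptor 9 (Homo sapiens), read by spectrophotometry (on this read-out lower numbers stand for stronger inhibition and higher numbers for weaker inhibition), the second highest of the three numbers recorded. Compound 1 `CCN1CCN(CCCn2cnc3c(N4CCN(C5CCCC5)CC4)nc(NCc4ccc(F)cc4)nc32)CC1` gives 250 nM in this assay, and compound 2 `CCN1CCN(CCCn2cnc3c(N4CCN(CC)CC4)nc(NCc4ccc(N(CC)CC)cc4)nc32)CC1` gives 440 nM; both of these sit within the scatter of compound 3. Compound 4 `CCN1CCN(CCCn2cnc3c(N4CCN(C5CCCC5)CC4)nc(NCc4ccc(N(CC)CC)cc4)nc32)CC1` carries 4-(diethylamino)benzyl in place of hydrogen on a nitrogen on an aromatic ring. For the measured compounds named here, the one single change measured at this nitrogen is a 1.1-fold higher number from compound 1 to compound 3 (0.05 log units; within the scatter), so placing a benzyl group there left the number within the scatter. Compound 2 bears the same 4-(diethylamino)benzyl group but differs elsewhere as well, so its number can only be set beside that of compound 3 without a step. The expected step is a 1.1-fold higher number from compound 3 to compound 4 (0.03 log units; within the scatter), nothing beyond the scatter. Compound 4 is estimated at 300 nM, with a range from 120 nM to 750 nM.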

Compound 4, half-maximal inhibitory concentration: 150 nM
Beside the measured number, compound 4's estimate is 2.0-fold (0.30 log units) above it; the range from low to high includes it.
By their numbers in this assay, from the lowest: compounds 4, 1, 3 and 2 (each within the scatter of the next, the first and the last beyond it).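

At the nitrogen on an aromatic ring, the 4-(diethylamino)benzyl group stays within the scatter of hydrogen (a 1.9-fold lower number from compound 3 to compound 4 (0.27 log units; within the scatter)), and diethylamino in place of fluoro on an aromatic carbon also stays within it (a 1.7-fold lower number from compound 1 to compound 4 (0.22 log units; within the scatter)). For the compounds shown here, the only one of these changes beyond the scatter lies elsewhere, with cyclopentyl in place of ethyl on an amine nitrogen in a ring (a 2.9-fold lower number from compound 2 to compound 4 (0.47 log units; beyond the scatter)). No available evidence accounts for these differences.

On these data alone, whether cyclohexyl or a hydroxyethyl chain on that amine nitrogen would move the number further remains open. So does the effect of a carboxylic acid or morpholine in place of diethylamino on the aromatic carbon.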